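The source may hold more compounds than are shown below. What is called first, only, known or untested is meant among the compounds shown, and "the series" means these compounds.

Measured in a functional assay on A549 cells (Homo sapiens) for cytotoxicity, read by MTT assay, with a stated time of 24 h; on this read-out higher numbers stand for weaker inhibition and lower numbers for stronger inhibition:
- compound 1 `FC(F)(F)C(F)(F)C(F)(F)C(F)(F)C(F)(F)C(F)(F)C(F)(F)C(F)(F)CCn1cc(COc2ccccc2-c2nc3ccccc3s2)nn1` gives 13100 nM
- compound 2 `c1ccc(-n2cc(COc3ccccc3-c3nc4ccccc4s3)nn2)cc1` gives 16400 nM
- compound 3 `COc1ccc(-c2nc3cc(F)ccc3s2)cc1OC` gives 15900 nM

All three numbers in this assay fall within the scatter of one another: the gap from compound 2 to compound 3 and the gap from compound 2 to compound 1 are both within the usual spread of repeated measurements, so compound 2 cannot be set apart from either of the others on these data. The series as a whole shows only weak inhibition in this assay.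

Compound 4 `FC(F)(F)c1cccc(-n2cc(COc3ccccc3-c3nc4ccccc4s3)nn2)c1` is not yet measured. It differs from compound 2 by trifluoromethyl in place of hydrogen on an aromatic carbon. No measured pair in this set carries the same change, so there is no shown step to lean on.

For the measured compounds named here, with the three measured numbers bunched together and no reference step for this change, the expectation for compound 4 is a step from compound 2 of a 1.2-fold lower number from compound 2 to compound 4 (0.07 log units; within the scatter), which is no more than the scatter. Compound 4 is therefore estimated at 14000 nM in this assay, with a range from 7000 nM to 30000 nM.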

Compound 4, half-maximal inhibitory concentration: 11100 nM
Compound 4: the middle estimate sits 1.3-fold (0.10 log units) above what was measured; low and high end bracket the measured number.
By their numbers in this assay, from the lowest: compounds 4, 1, 3 and 2 (each within the scatter of the next).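

In this assay, for the compounds shown here, the change from phenyl to 3-(trifluoromethyl)phenyl gives a 1.5-fold lower number from compound 2 to compound 4 (0.17 log units; within the scatter) as the only single-place step in the set. This aromatic carbon therefore accepts trifluoromethyl in place of hydrogen with no shift that can be separated from repeat variation, and compound 4 stays in the same weak range as the rest of the series. No supporting data bear on this result.

Going by these compounds, whether an amine or a carboxylic acid at this position would move the number beyond the scatter remains open. Going by these compounds alone, with only one step available, it is also unknown whether trifluoromethyl on other carbons of this phenyl ring would give a similarly small step.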